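Cyclopropyl for propyl on the carbonyl of compound 2

The source may report more compounds than this note shows. Statements on the series, on what has been measured and on what is new or still open speak of the compounds shown alone.

- compound 1 `CCOC(=O)c1cc(-c2ccc(F)cc2)n(-c2ccc(S(N)(=O)=O)cc2)c1N` gives 7500 nM
- compound 2 `CCCC(=O)c1cc(-c2ccc(S(N)(=O)=O)cc2)n(-c2ccc(Cl)cc2)n1` gives 25800 nM

In a physicochemical assay for solubility, read by HPLC, in phosphate buffer, measured as kinetic solubility, at pH 7.4 (a higher number here means a more soluble compound, a lower number a less soluble compound), compound 2 reads 25800 nM and stands above compound 1 at 7500 nM by more than the scatter. Going by the values given here, these two compounds differ in more than one place, so no measured step bears on the next change. Compound 3 `NS(=O)(=O)c1ccc(-c2cc(C(=O)C3CC3)nn2-c2ccc(Cl)cc2)cc1`, not yet measured, carries cyclopropyl in place of propyl on a carbonyl carbon. The expected size is a 1.1-fold higher number from compound 2 to compound 3 (0.04 log units; within the scatter), with no change beyond the scatter anticipated in this assay and no firm direction. Compound 3 is estimated at 28000 nM (expected range 12000 nM to 60000 nM).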

Compound 3, solubility: 25600 nM
The estimate for compound 3 lay 1.1-fold (0.04 log units) above the measured number; low and high end bracket the measured number.
By their numbers in this assay, from the lowest: compound 1; then compounds 3 and 2 (each within the scatter of the next).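

Going by these compounds alone, on the carbonyl carbon, cyclopropyl in place of propyl is the only single-place step so far: in this assay it reads a 1.0-fold lower number from compound 2 to compound 3 (0.00 log units; within the scatter) and stays within the scatter. For this one pair, closing the chain into a three-membered ring of carbon leaves the read-out where it was. Nothing at hand bears on why.

On these data alone, whether an amine, a carboxylic acid or a longer chain on this carbonyl would read differently stays open. Compound 1 differs from compound 2 in more than one place, so the gap between them cannot be tied to any single change.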